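The compounds below may be only part of what the source reports. "The series", "measured", "known", "first", "only" and "open" are said of these compounds alone.

In an ADME assay on microsomes from liver (Rattus norvegicus) for metabolic stability, with a stated time of 10 min (on this read-out higher numbers stand for a more stable compound and lower numbers for a less stable compound), compound 1 (`COc1cc(C)c(Nc2nc(Cl)cn([C@H](C)C3CC3)c2=O)c(C)n1`) gives 79% and compound 2 (`COc1nc(C)c(Nc2nc(Cl)cn([C@H](C)C3CC3)c2=O)c(OC)n1`) gives 86% on the same scale. Compound 3 (`COC[C@@H](C1CC1)n1cc(Cl)nc(Nc2c(C)nc(OC)nc2OC)c1=O`) carries 1-cyclopropyl-2-methoxyethyl in place of 1-cyclopropylethyl on an aromatic nitrogen, and compound 3 reads 71% in this test. That places compound 3 within the scatter of compound 1, whereas compound 2 stands higher by more than the scatter.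

Compound 4 (`COC[C@H](C1CC1)n1cc(Cl)nc(Nc2c(C)nc(OC)nc2OC)c1=O`) has not yet been measured. Its relation to compound 3 is simple to state: the two compounds have the same atoms and bonds and differ only in configuration as drawn: 1 of 1 stereo elements differ; a stereocentre at a saturated chain carbon is drawn R in compound 3 and S in compound 4 is the whole of the change. Among the measured compounds shown here, only one measured step bears on the question, and it shows a number 15 percentage points lower from compound 2 to compound 3 (beyond the scatter) for the swap of side chains. That step changes atoms, so it does not measure configuration, and no pair among these compounds differs in configuration alone. From the compounds shown here alone, the size of such a step therefore remains unknown, and the modest side-chain step serves only as a guide to how wide the range should be. The expected outcome is no shift beyond the scatter, and the estimated step is a number 1 percentage points higher from compound 3 to compound 4 (within the scatter) in this assay overall. Compound 4 is expected at 72%, with an estimated range from 58% to 85% for this measurement.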

Compound 4, percent of the compound remaining: 45%
Beside the measured number, compound 4's estimate is 27 percentage points above it; the whole stated range lies above it.
By their numbers in this assay, from the lowest: compound 4; then compounds 3, 1 and 2 (each within the scatter of the next, the first and the last beyond it).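

In this assay, among the compounds shown here, the configuration at the saturated chain carbon proves to matter, a point the earlier compounds could not address, with a number 26 percentage points lower from compound 3 to compound 4 (beyond the scatter). This step can be assigned to configuration alone, because nothing else separates the pair: the fact that compounds 3 and 4 differ only in the configuration as drawn. It also changes how the side-chain swap reads, since methoxy in place of hydrogen on that chain carbon gives a number 15 percentage points lower from compound 2 to compound 3 (beyond the scatter) when the stereocentre is drawn R, but a number 41 percentage points lower from compound 2 to compound 4 (beyond the scatter) when it is drawn S, so the earlier step described only one of the two configurations.

The compounds shown leave open whether inverting the stereocentre of the 1-cyclopropylethyl group in compound 1 or compound 2 would also produce a step beyond the scatter, or whether the dependence on configuration appears only when the methoxy group is present. They also leave open whether a hydroxy group or an ethoxy group on the same chain carbon would show a similar gap between its R and S forms, and they do not show which part of compound 4 accounts for its lower reading.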